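Extending the Amide Alkyl Chain of Compound 2

This account rests on a few compounds, and the source may have more. Where it says the series, first, only, none or still open, it means among the compounds named here.

Measured compounds:
- Compound 1, `CCNC(=O)c1cc(Oc2ccc(NC(=O)c3cc4cccnc4n(-c4ccc(Cl)cc4)c3=O)cc2)ccn1`: in a functional assay on A549 cells (Homo sapiens) for antiproliferative activity, read by MTT assay, with a stated time of 72 h (a lower number here means a stronger inhibitor, a higher number a weaker inhibitor), compound 1 gives 250 nM.
- Compound 2, `CCNC(=O)c1cc(Oc2ccc(NC(=O)c3cc4cccnc4n(-c4ccc(OC)cc4)c3=O)cc2)ccn1`: in this assay compound 2 gives 2010 nM.
- Compound 3, `CCNC(=O)c1cc(Oc2ccc(NC(=O)c3cc4cccnc4n(-c4ccc(Br)cc4F)c3=O)cc2)ccn1`: in this assay compound 3 gives 1820 nM.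

Compound 2 carries the highest number of the three: an 8.0-fold higher number from compound 1 to compound 2 (0.91 log units; beyond the scatter) sets it clearly apart from compound 1, while a 1.1-fold lower number from compound 2 to compound 3 (0.04 log units; within the scatter) leaves it indistinguishable from compound 3. Compound 4, `CCCNC(=O)c1cc(Oc2ccc(NC(=O)c3cc4cccnc4n(-c4ccc(OC)cc4)c3=O)cc2)ccn1`, differs from compound 2 by methyl in place of hydrogen on a saturated chain carbon, two bonds along the chain from an amide-type nitrogen. Among the measured compounds shown here, every measured step, an 8.0-fold higher number from compound 1 to compound 2 (0.91 log units; beyond the scatter), a 7.3-fold higher number from compound 1 to compound 3 (0.86 log units; beyond the scatter) and a 1.1-fold lower number from compound 2 to compound 3 (0.04 log units; within the scatter), alters the aryl group on the aromatic nitrogen of the shared core; none touches the ethylamino end, so no measured step bears directly on this change. With no matched comparison, there is no basis for expecting a shift beyond the scatter in either direction. Compound 4 is therefore expected to give about 2000 nM in this assay, within 800 nM to 5000 nM. For the measured compounds named here, the expected step of a 1.0-fold lower number from compound 2 to compound 4 (0.00 log units; within the scatter) is essentially flat, with the range widened because no measured pair speaks to this position.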

Compound 4, half-maximal inhibitory concentration: 820 nM
For compound 4 the middle estimate is 2.4-fold (0.39 log units) above the measured one; measured number inside the range.
By their numbers in this assay, from the lowest: compound 1; then compound 4; then compounds 3 and 2 (each within the scatter of the next).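

Unlike the earlier steps, which all alter the aryl group on the aromatic nitrogen of the shared core, this change from ethylamino to propylamino acts at the other end of the molecule, and it gives a 2.5-fold lower number from compound 2 to compound 4 (0.39 log units; beyond the scatter) in this assay. The amide alkyl chain is therefore not a silent position: methyl in place of hydrogen on a saturated chain carbon moves compound 4 modestly towards a stronger inhibitor, although it remains on the weaker side of compound 1 at 250 nM, which carries a different aryl group and the shorter chain. Nothing available here accounts for this shift.

On these data alone, whether a longer chain such as butyl, or a branched isopropyl group, would continue the trend remains open. So does whether propylamino would bring a similar step with the 4-chlorophenyl group of compound 1.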